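The compounds below may be only part of what the source reports. "The series", "measured", "known", "first", "only" and "open" are said of these compounds alone.

Values measured in a functional assay on HT cells (Homo sapiens) for antiproliferative activity, read by fluorescence, with a stated time of 72 h (a lower number here means a stronger inhibitor of growth, a higher number a weaker inhibitor of growth), are as follows.

- compound 1 `CC(C)c1n[nH]c2c(NCc3ccc(-c4ccccn4)cc3)nc(SCC(N)CN)nc12` gives 480 nM
- compound 2 `CC(C)c1n[nH]c2c(NCc3ccc(-c4ccccn4)cc3)nc(SC[C@H](O)CN)nc12` gives 63 nM
- compound 3 `CNCCSc1nc(NCc2ccc(-c3ccccn3)cc2)c2[nH]nc(C(C)C)c2n1` gives 56 nM

Compound 3 stands at the low end of these numbers, but it has company there: the data show a 1.1-fold lower number from compound 2 to compound 3 (0.05 log units; within the scatter) so that pair counts as level. The high end stands clearly apart, with an 8.6-fold lower number from compound 1 to compound 3 (0.93 log units; beyond the scatter) and a 7.6-fold lower number from compound 1 to compound 2 (0.88 log units; beyond the scatter) as the two larger steps, both modest.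

The next compound is compound 4 `CC(=O)NCCSc1nc(NCc2ccc(-c3ccccn3)cc2)c2[nH]nc(C(C)C)c2n1` and its difference from compound 3 is acetyl in place of methyl on an amine nitrogen in which acetyl takes the place of methyl on an amine nitrogen, so that 2-(methylamino)ethyl becomes 2-acetamidoethyl.

For the measured compounds named here, no measured step makes this exact change. The nearest evidence is the three steps above, which all alter the same chain bound to sulfur. They range from no real change to the size of an 8.6-fold lower number from compound 1 to compound 3 (0.93 log units; beyond the scatter) and so offer only a rough scale. Turning the amine into an amide is a real change to that chain, so a modest rise in this assay is the likelier outcome, though a result level with compound 3 remains possible.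

The expected move is a 3.0-fold higher number from compound 3 to compound 4 (0.48 log units; beyond the scatter) as an estimate only. For compound 4 the estimated value is 170 nM with an expected range from 45 nM to 600 nM around it.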

Compound 4, concentration for 50% growth inhibition: 71 nM
The estimate for compound 4 lay 2.4-fold (0.38 log units) above the measured number, and the stated range covers the measured number.
By their numbers in this assay, from the lowest: compounds 3, 2 and 4 (each within the scatter of the next); then compound 1.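

In this assay, acetyl in place of methyl on the amine nitrogen gives a 1.3-fold higher number from compound 3 to compound 4 (0.10 log units; within the scatter), so this change, which brings in a carbonyl, leaves the number level and shows that the end of the sulfur-bound chain can carry an acetamido group as well as a methylamino group. For the compounds shown here, the chain with the 2-acetamidoethyl group also reads level with the one bearing a hydroxyl group, at a 1.1-fold higher number from compound 2 to compound 4 (0.05 log units; within the scatter), while the gap to the 1,2-diaminoethyl-type chain remains clear, at a 6.8-fold lower number from compound 1 to compound 4 (0.83 log units; beyond the scatter), which leaves compound 1 as the only one of the four set apart. Nothing measured here explains why such different chain ends read alike.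

As far as these compounds go, it remains open whether this tolerance extends to a larger acyl group such as benzoyl, or to a sulfonamide, on the same nitrogen. A plain primary amine, a carboxylic acid at the chain end and a longer chain between the sulfur and the nitrogen are also untested by the compounds shown, so how far the chain can vary is still unknown.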